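Side-chain swap on a shared acid core

A few compounds are considered here, and "the series" means these few. Any claim that something is new, unique, unknown or untested is made for them only; others in the source may bear on it.

Compound 1 `O=C(O)[C@@H]1CCCN1C(=O)CN(c1nc(Cl)nc2[nH]cnc12)C1CC1` gives 34.9% in a functional assay on the whole organism (Tail, strain ICR) with Mus musculus as the target, in the tail flick test, with a stated time of 60 min, at a dose of 25 umol/kg by the oral route; on this read-out higher numbers stand for a stronger effect at the one dose given and lower numbers for a weaker effect.
Compound 2 `C[C@@H](O)[C@H](NC(=O)CN(c1nc(Cl)nc2[nH]cnc12)C1CC1)C(=O)OCc1ccccc1` gives 29.7% in this assay.
Compound 3 `C[C@@H](O)[C@H](NC(=O)CN(c1nc(Cl)nc2[nH]cnc12)C1CC1)C(=O)O` gives 30.1% in this assay.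

Compound 3 holds the second highest of the three numbers, though all three sit within the scatter of one another: its nearest neighbour is compound 2 and its furthest is compound 1, and neither gap counts as a real difference. The two measured steps that reach compound 3 are a number 4.8 percentage points lower from compound 1 to compound 3 (within the scatter) and a number 0.4 percentage points higher from compound 2 to compound 3 (within the scatter), both within the scatter, so changing the acid-bearing portion or removing the benzyl from the ester oxygen left the read-out where it was.

Compound 4 `CC(C)C[C@H](NC(=O)CN(c1nc(Cl)nc2[nH]cnc12)C1CC1)C(=O)O` differs from compound 3 by isobutyl in place of 1-hydroxyethyl on a saturated chain carbon bound to an amide-type nitrogen and a carbonyl carbon. Among the measured compounds shown here, neither measured step exchanges this side chain, so there is no direct precedent; the nearest guide is that the acid portion could be rebuilt in compound 1 to compound 3 without effect beyond the scatter. Compound 4 is therefore expected to show a step of a number 0.1 percentage points lower from compound 3 to compound 4 (within the scatter), that is, none beyond the scatter. Compound 4 is estimated at 30%, with a range from 17% to 43%.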

Compound 4, a percentage reported as activity, at one dose (the size of the read-out at that dose, not a potency): 36.4%
Estimate against measurement, compound 4: 6.4 percentage points below, and the stated range covers the measured number.
By their numbers in this assay, from the lowest: compounds 2, 3, 1 and 4 (each within the scatter of the next).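

This is the first change shown on a saturated chain carbon bound to an amide-type nitrogen and a carbonyl carbon, and exchanging 1-hydroxyethyl for isobutyl gives a number 6.3 percentage points higher from compound 3 to compound 4 (within the scatter) in this assay. The side chain can therefore lose its hydroxyl group and gain an all-carbon branch without a real difference in this read-out, so on these numbers the hydrogen-bond donor and acceptor counted in 1-hydroxyethyl are not needed to retain the effect at the one dose given. Nothing shown explains this result.

From the compounds shown here alone, whether an amine or a carboxylic acid on this side chain, or a longer chain, would move the read-out beyond the scatter remains open. With a single dose for each compound, the numbers also leave open whether these compounds differ in potency.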